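Iodo for bromo in two amide sub-series

The compounds below may be only part of what the source reports. "The series", "measured", "known", "first", "only" and "open" are said of these compounds alone.

Measured compounds:
Compound 1, `O=C(Nc1nnc(-c2ccc(Cl)cc2)s1)c1ccccc1Br`: in a functional assay on the whole organism (integument) for inhibition, with Chilo suppressalis as the target, read by scintillation counting, with a stated time of 72 h (a lower number here means a stronger inhibitor, a higher number a weaker inhibitor), compound 1 gives > 5010 nM, a limit of the assay rather than a number.
Compound 2, `O=C(Nc1nnc(-c2ccc(Cl)cc2)s1)c1ccccc1I`: in this assay compound 2 gives > 5010 nM, again a limit and not a number.
Compound 3, `COc1cccc(OC)c1C(=O)Nc1nnc(-c2ccc(Br)cc2)s1`: in this assay compound 3 gives 66.1 nM.

Compound 1 and compound 2 share a core and differ by iodo in place of bromo on an aromatic carbon. The step that the two limits leave unreadable from compound 1 to compound 2 has no readable size, since both values sit at the limit of > 5010 nM in this assay, at which 2 of the 3 values shown sit. Compound 3 carries a different core; the difference between the two cores is not broken down here. Among the measured compounds shown here, compound 3 is the only compound with a number in this assay, the other two values being limits.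

Compound 4, `COc1cccc(OC)c1C(=O)Nc1nnc(-c2ccc(I)cc2)s1`, is not yet measured and differs from compound 3 by iodo in place of bromo on an aromatic carbon. This is the same kind of change as that from compound 1 to compound 2, but the surroundings differ: there the halogen sits ortho to a large group, here para to a large group. The earlier step gives no usable size, so the expectation for compound 4 rests on the value of compound 3 and on the small size of the exchange. Compound 4 is expected near 70 nM, with a likely range from 30 nM to 170 nM. The step of a 1.1-fold higher number from compound 3 to compound 4 (0.02 log units; within the scatter) is expected to be small.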

Compound 4, half-maximal inhibitory concentration: 89.1 nM
Compound 4: the middle estimate sits 1.3-fold (0.10 log units) below what was measured; low and high end bracket the measured number.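

Iodo in place of bromo, para to a large group, reads in this assay as a 1.3-fold higher number from compound 3 to compound 4 (0.13 log units; within the scatter), so in this core the two halogens cannot be told apart. Among the compounds shown here, whether this result carries from one core to another stays untested, since the step on the core of compound 1 cannot be read and both compounds of that pair sit at a limit of the assay rather than at a number: the limit of > 5010 nM in this assay, at which 2 of the 4 values shown sit. The one readable step is therefore a single case and not a rule for the series.

Open, on these data alone, is whether a group of another kind in place of the bromo, such as fluoro, a nitrile or an amine, would give a value close to these two in this assay. The difference between the two cores also remains unsplit into single changes among the compounds shown.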